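Cyclohexyl to isopropyl on a quinoline series, second instance

This account rests on a few compounds, and the source may have more. Where it says the series, first, only, none or still open, it means among the compounds named here.

Three compounds sharing a common core have been examined for cytotoxicity. Compound 2 `c1coc(CNCCCNc2ccnc3cc(CC4CCCCC4)ccc23)c1` gives 1700 nM in an ADME assay on HepG2 cells (Homo sapiens) for cytotoxicity, read by luminescence, CellTiter-Glo and ATP content, with a stated time of 72 h; a lower number here means that less compound is needed, a higher number that more compound is needed for the effect. Compound 1 `CC(C)Cc1ccc2c(NCCCNCc3ccco3)ccnc2c1` differs from it by one change, (isopropyl in place of cyclohexyl on a saturated chain carbon bound to an aromatic carbon), and in this assay compound 1 gives 16000 nM, a step of a 9.4-fold higher number from compound 2 to compound 1 (0.97 log units; beyond the scatter). Compound 3 `COc1ccc(F)cc1CNCCCNc1ccnc2cc(CC3CCCCC3)ccc12` carries a different change on the other end of the chain, (5-fluoro-2-methoxyphenyl in place of furan-2-yl on a saturated chain carbon bound to an amine nitrogen), and in this assay compound 3 gives 1830 nM; the step is a 1.1-fold higher number from compound 2 to compound 3 (0.03 log units; within the scatter), so the two values cannot be told apart.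

Compound 4 `COc1ccc(F)cc1CNCCCNc1ccnc2cc(CC(C)C)ccc12` has not yet been measured. It stands to compound 3 as compound 1 stands to compound 2: the change is isopropyl in place of cyclohexyl on a saturated chain carbon bound to an aromatic carbon, and the place line for this change reads word for word the same as in the earlier pair, so it is the same change. The cores on which it is made differ by 5-fluoro-2-methoxyphenyl in place of furan-2-yl on a saturated chain carbon bound to an amine nitrogen, a difference that on its own produced no step beyond the scatter.

For the measured compounds named here, with only one prior instance to go on, the expected step from compound 3 to compound 4 in this assay is an 8.7-fold higher number from compound 3 to compound 4 (0.94 log units; beyond the scatter), which rests on the earlier step of a 9.4-fold higher number from compound 2 to compound 1 (0.97 log units; beyond the scatter). On that basis compound 4 is estimated at 16000 nM, with a plausible range from 6000 nM to 45000 nM. Whether the second instance follows the first remains to be seen.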

Compound 4, half-maximal effective concentration: 2900 nM
For compound 4 the middle estimate is 5.5-fold (0.74 log units) above the measured one; measured number outside the range, below it.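

In this assay the replacement of cyclohexyl by isopropyl did not carry over from one core to the other in size. On the core bearing 5-fluoro-2-methoxyphenyl the step is a 1.6-fold higher number from compound 3 to compound 4 (0.20 log units; within the scatter), and set beside the earlier step it differs: the same change on two cores in this assay, a 9.4-fold higher number (0.97 log units; beyond the scatter) from compound 2 to compound 1 and a 1.6-fold higher number (0.20 log units; within the scatter) from compound 3 to compound 4, 5.9-fold (0.77 log units) apart, beyond the scatter of two such steps. Read the other way round, 5-fluoro-2-methoxyphenyl in place of furan-2-yl gives a 5.5-fold lower number from compound 1 to compound 4 (0.74 log units; beyond the scatter) when isopropyl is present, which also differs from the step measured with cyclohexyl present: the same change on two cores in this assay, a 1.1-fold higher number (0.03 log units; within the scatter) from compound 2 to compound 3 and a 5.5-fold lower number (0.74 log units; beyond the scatter) from compound 1 to compound 4, 5.9-fold (0.77 log units) apart, beyond the scatter of two such steps. Among these four compounds the two changes therefore do not act independently, but with a single pair on each core this does not show which feature of the cores sets the size of the step, nor how a further core would behave.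

The compounds shown leave open whether the large step seen with furan-2-yl or the small one seen with 5-fluoro-2-methoxyphenyl is the more usual in this series. They also leave open what a straight propyl chain or a phenyl group in place of cyclohexyl, or an unsubstituted phenyl in place of furan-2-yl, would give on these cores.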